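Pyrazole series: chloro to trifluoromethoxy on the pendant phenyl

The source may hold more compounds than are shown below. What is called first, only, known or untested is meant among the compounds shown, and "the series" means these compounds.

Compound 1 `Cc1ccccc1-c1nn(-c2ccc(Cl)cc2)cc1CNCCN1CCN(C)CC1` and compound 3 `Cc1ccccc1-c1nn(-c2ccc(OC(F)(F)F)cc2)cc1CNCCN1CCN(C)CC1` share a core and differ by trifluoromethoxy in place of chloro on an aromatic carbon. In an ADME assay on Huh-7 cells (Homo sapiens) for cytotoxicity (on this read-out lower numbers stand for higher toxicity in this test and higher numbers for lower toxicity in this test), compound 1 gives 17000 nM and compound 3 gives 17000 nM, so the step of no change at the digits printed from compound 1 to compound 3 (within the scatter). Compound 2 `CN1CCN(CCCNCc2cn(-c3ccc(C(F)(F)F)cc3)nc2-c2ccc(Cl)cc2)CC1` sits on a different core; the difference between the two cores is not broken down here. In this assay compound 2 gives 2500 nM, the lowest of the three numbers and beyond the scatter from both compound 1 and compound 3. Compound 4 `CN1CCN(CCCNCc2cn(-c3ccc(C(F)(F)F)cc3)nc2-c2ccc(OC(F)(F)F)cc2)CC1` is not yet measured and differs from compound 2 by trifluoromethoxy in place of chloro on an aromatic carbon, the same change that was made from compound 1 to compound 3, with the same surroundings at the place of exchange. Since that earlier step left the number unchanged within the scatter, the expectation for compound 4 in this assay is a step of no change at the digits printed from compound 2 to compound 4 (within the scatter), essentially flat, with the usual spread of repeat measurements around it. The estimate for compound 4 is thus 2500 nM, between 1000 nM and 6500 nM.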

Compound 4, half-maximal cytotoxic concentration: 2300 nM
Beside the measured number, compound 4's estimate is 1.1-fold (0.04 log units) above it; the measured number falls inside the stated range.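

In this assay, trifluoromethoxy in place of chloro on the core of compound 2 gives a 1.1-fold lower number from compound 2 to compound 4 (0.04 log units; within the scatter). Set beside the same exchange on the core of compound 1, the result carries over from one core to the other: the same change on two cores in this assay, no change at the digits printed (within the scatter) from compound 1 to compound 3 and a 1.1-fold lower number (0.04 log units; within the scatter) from compound 2 to compound 4, 1.1-fold (0.04 log units) apart, within the scatter of two such steps. For these two matched pairs, the exchange can therefore be treated as neutral in this read-out, but two pairs do not make a rule for other cores or other read-outs, and they neither explain the flat result nor say what separates the two cores.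

The compounds shown leave open whether other groups at the same place on the aromatic ring, such as fluoro, methoxy, a nitrile or an amine, would also leave the number flat. They also leave open whether the exchange stays neutral on a core with a longer chain carrying the basic amine, or with a carboxylic acid added.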